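The source may hold more compounds than are shown below. What is called first, only, known or untested is meant among the compounds shown, and "the series" means these compounds.

- compound 1 `O=C(CCCCCCOc1ccc(-c2nnc(-c3ccccc3)s2)cc1)NO`: 3100 nM
- compound 2 `O=C(CCCCOc1cccc(-c2nnc(-c3ccccc3)s2)c1)NO`: 490 nM

Both values come from a functional assay on MOLT-4 cells (Homo sapiens) for antiproliferative activity, read by CCK-8 assay, with a stated time of 48 h; on this read-out lower numbers stand for stronger inhibition and higher numbers for weaker inhibition. Of the two numbers, compound 2 has the lower one, and the gap to compound 1 lies beyond the usual scatter. Compound 3 `O=C(CCCCCOc1cccc(-c2nnc(-c3ccccc3)s2)c1)NO` has not yet been measured in this assay. It differs from compound 2 in one place: (hydroxycarbamoyl)methyl in place of hydroxycarbamoyl on a saturated chain carbon, four bonds along the chain from an oxygen on an aromatic ring. In words, (hydroxycarbamoyl)methyl stands in place of hydroxycarbamoyl on a saturated chain carbon, four bonds along the chain from an oxygen on an aromatic ring. Going by the values given here, no measured pair of compounds shows a change of this kind on its own, so the data give no direct guide to its size. The expectation therefore starts from compound 2 at 490 nM and allows a wide margin on either side. A slightly lower number is expected, but no step beyond the scatter, and the estimated move is a 1.4-fold lower number from compound 2 to compound 3 (0.15 log units; within the scatter). For compound 3 the expected value is 350 nM, with an estimated range from 120 nM to 1100 nM.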

Compound 3, half-maximal inhibitory concentration: 150 nM
For compound 3 the middle estimate is 2.3-fold (0.37 log units) above the measured one; measured number inside the range.
By their numbers in this assay, from the lowest: compound 3; then compound 2; then compound 1.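

In this assay, replacing hydroxycarbamoyl with (hydroxycarbamoyl)methyl on a saturated chain carbon, four bonds along the chain from an oxygen on an aromatic ring, gives a 3.3-fold lower number from compound 2 to compound 3 (0.51 log units; beyond the scatter). Compounds 1 and 2 differ in more than one place, so their numbers could not isolate any single change, whereas this pair shows that the read-out responds to a change at this position alone, one that adds a carbon to the count while the counted hydrogen-bond donors and acceptors stay the same and neither group carries a net charge. Nothing available explains why the number falls with this change.

As far as these compounds go, a single step cannot show whether the trend continues, so it remains open whether 2-(hydroxycarbamoyl)ethyl or 3-(hydroxycarbamoyl)propyl at the same place would lower the number further, level off or reverse the step. From the compounds shown here alone, it is also open how much of the result depends on the hydroxycarbamoyl end itself, which a carboxylic acid or a primary amide at the end of the same chain would test.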